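Methoxy added to the phenyl of compound 1

The source may report more compounds than this note shows. Statements on the series, on what has been measured and on what is new or still open speak of the compounds shown alone.

Measured so far:
compound 1, `O=C(c1cc(-c2ccccc2)on1)N(C1CCCCC1)C1CCCCC1`: > 50000 nM
compound 2, `O=C(c1cc(C2CC2)on1)N(C1CCCCC1)C1CCCCC1`: > 50000 nM
compound 3, `CC1CCCCC1N(C(=O)c1cc(C2CC2)on1)C1CCCCCC1`: > 50000 nM

In an assay on isolated protein for agonist activity at sphingosine 1-phosphate receptor 4 (Homo sapiens) (a lower number here means that less compound is needed, a higher number that more compound is needed for the effect), compound 1 gives only a limit, > 50000 nM. Compound 2 likewise stops at a limit, > 50000 nM. Compound 3 too shows only a limit, > 50000 nM. The step that the two limits leave unreadable from compound 1 to compound 2 therefore has no readable size; it is hidden by the limit of > 50000 nM in this assay, at which 3 of the 3 values shown sit.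

Compound 4, `COc1ccc(-c2cc(C(=O)N(C3CCCCC3)C3CCCCC3)no2)cc1`, differs from compound 1 by methoxy in place of hydrogen on an aromatic carbon. Among the compounds with values here, the only measured step that touches this phenyl is the unreadable one, so nothing here foretells a shift beyond the scatter in either direction. Compound 4 is therefore expected to sit again at the limit, around 50000 nM, within 15000 nM to 100000 nM. The expected step is a number no higher from compound 1 to compound 4 (the limit leaves the size open).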

Compound 4, half-maximal effective concentration: > 50000 nM
Compound 4: a limit, no number (the forecaster's own chance of this, stated with the estimate: 80%); the middle value sits exactly at the limit.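

Compound 4 also gives only a limit, so the steps to it from compound 1 and compound 2 cannot be read: the limit of > 50000 nM in this assay, at which 4 of the 4 values shown sit.

The compounds shown leave open which change, if any, would give a readable value in this assay.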